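The source may report more compounds than this note shows. Statements on the series, on what has been measured and on what is new or still open speak of the compounds shown alone.

Compound 1, with the structure `O=C(O)CSc1cccc(NC(=O)CN2N=C(C3CCCCC3)c3ccccc3N(CC(=O)C3CCCC3)C2=O)c1`, is one of two compounds that have been measured so far. In a functional assay on gastric mucosa for displacement of a labelled ligand from Gastrin/cholecystokinin type B receptor (Canis lupus familiaris), read by CCK-8 assay (a higher number here means a weaker inhibitor, a lower number a stronger inhibitor), compound 1 gives 4.79 nM. The other measured compound, compound 2, has the structure `CC(C)(C)C(=O)CN1C(=O)N(CC(=O)Nc2cccc(-c3nn[nH]n3)c2)N=C(C2CCCCC2)c2ccccc21` and in this assay compound 2 gives 3.16 nM. These two numbers lie within the scatter of repeated measurements of each other, so compound 1 and compound 2 cannot be told apart on the evidence at hand, and neither can be called the stronger inhibitor.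

Compound 3, with the structure `O=C(CN1N=C(C2CCCCC2)c2ccccc2N(CC(=O)C2CCCC2)C1=O)Nc1cccc(C(=O)O)c1`, has not yet been measured. It differs from compound 1 in one place: carboxy in place of (carboxymethyl)sulfanyl on an aromatic carbon. For the measured compounds named here, no step between two measured compounds shows what such a change does here, and the only comparison available, compound 1 against compound 2, involves a different change altogether. The acid group is kept, only moved closer to the ring and shortened. The step of a 1.3-fold higher number from compound 1 to compound 3 (0.10 log units; within the scatter) is therefore expected to be small, within or only just beyond the scatter, and in either direction. Compound 3 is estimated to give 6 nM in this assay, with a plausible range from 2 nM to 20 nM.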

Compound 3, inhibition constant: 7.08 nM
For compound 3 the middle estimate is 1.2-fold (0.07 log units) below the measured one, and the stated range covers the measured number.
By their numbers in this assay, from the lowest: compounds 2, 1 and 3 (each within the scatter of the next, the first and the last beyond it).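

For the compounds shown here, replacing (carboxymethyl)sulfanyl with carboxy on this aromatic carbon, in this assay, is the first change at this position that can be read directly (a 1.5-fold higher number from compound 1 to compound 3 (0.17 log units; within the scatter)). The substituent goes from 5 heavy atoms to 3 and loses its sulfur, yet the two compounds cannot be told apart, so on this pair the sulfur and the extra carbon make no difference that the measurement can resolve. No measured information is available to explain this result.

Both substituents still contain a carboxy group, so this pair cannot show whether a carboxylic acid matters at this position; a compound carrying an amine or a methyl ester on the same aromatic carbon, with the rest of compound 3 unchanged, would address that. The pair also leaves open how a longer chain ending in a carboxylic acid would read here, and whether the carboxy group would give a similar number on a different carbon of the same six-membered aromatic ring.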